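The source may report more compounds than this note shows. Statements on the series, on what has been measured and on what is new or still open speak of the compounds shown alone.

Three compounds have been measured so far in a functional assay on HEK293 cells for activation of melanin-concentrating hormone receptor 1 (Homo sapiens), read by inositol phosphate accumulation; a higher number here means that more compound is needed for the effect, a lower number that less compound is needed:

compound 1, `CCc1cc(N)c2cc(NC(=O)/C=C/c3ccc(C(F)(F)F)cc3)ccc2n1`, gives 110 nM
compound 2, `CCCc1cc(N)c2cc(NC(=O)/C=C/c3ccc(Cl)cc3Cl)ccc2n1`, gives 904 nM
compound 3, `CCCc1cc(N)c2cc(NC(=O)/C=C/c3ccc(C(C)(C)C)cc3)ccc2n1`, gives 910 nM

Compound 1 stands lowest of the three in this assay, and its distance to compound 2 and to compound 3 lies beyond the usual scatter, so it is the most potent of this small set. Going by the values given here, compound 2 and compound 3 each differ from compound 1 in more than one place, so no single step between measured compounds can be isolated from these numbers; they only show that the two propyl-bearing compounds sit well above compound 1.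

Compound 4, `Nc1cc(C2CCCCC2)nc2ccc(NC(=O)/C=C/c3ccc(C(F)(F)F)cc3)cc12`, has not yet been measured. It keeps the core and the trifluoromethyl-bearing side chain of compound 1 and changes one group: cyclohexyl in place of ethyl on an aromatic carbon. The ethyl, two heavy atoms, leaves, and a cyclohexyl, a six-membered non-aromatic ring of carbon only, enters next to the ring nitrogen, meta to the amino group.

Among the compounds with values here, no measured pair shows what such a change does here, so the expectation is loose. The step from compound 1 to compound 4 in this assay is expected to be a modest rise, a 2.3-fold higher number from compound 1 to compound 4 (0.36 log units; beyond the scatter), though a step within the scatter would not be surprising. Compound 4 is therefore estimated at 250 nM, within a range from 50 nM to 1500 nM.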

Compound 4, half-maximal effective concentration: 96 nM
Estimate against measurement, compound 4: 2.6-fold (0.42 log units) above; measured number inside the range.
By their numbers in this assay, from the lowest: compounds 4 and 1 (each within the scatter of the next); then compounds 2 and 3 (each within the scatter of the next).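

In this assay, cyclohexyl in place of ethyl on this aromatic carbon gives a 1.1-fold lower number from compound 1 to compound 4 (0.06 log units; within the scatter), so the two compounds cannot be told apart by this read-out. Going by these compounds alone, this is the first comparison in the set where only one place differs, and it shows that a ring of carbon only can stand next to the ring nitrogen, in the position held by ethyl in compound 1, with no step beyond the scatter. Nothing in the data shown gives a reason for this outcome.

Ethyl and cyclohexyl are the only two groups compared at this position with the trifluoromethyl-bearing side chain held constant, so it remains open whether a phenyl ring, an amine, a carboxylic acid or a longer chain would also leave the number within the scatter. From the compounds shown here alone, it is also open whether cyclohexyl would give a similar result alongside the side chains of compound 2 and compound 3, since neither of those compounds forms a one-place pair with a cyclohexyl partner.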